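Swapping Methoxy for Chloro on a Shared Anilino Triazine

The source may hold more compounds than are shown below. What is called first, only, known or untested is meant among the compounds shown, and "the series" means these compounds.

Compound 1 `COc1ccc(Nc2nc(N)nc(CSc3nc4ccccc4[nH]3)n2)cc1` was tested in an ADME assay on Vero cells (Chlorocebus sabaeus) for cytotoxicity, read by resazurin assay, with a stated time of 3 days (on this read-out lower numbers stand for higher toxicity in this test and higher numbers for lower toxicity in this test), where for compound 1 the entry reads "not determined" (no result reported), so compound 1 stands without a number. Two related compounds were also examined: compound 2 `COc1ccc(Nc2nc(N)nc(CSc3nnc(-c4ccncc4)n3-c3ccccc3)n2)cc1`, which in this assay gives 1500 ug/mL, and compound 3 `Cc1ccc2[nH]c(SCc3nc(N)nc(Nc4ccccc4C)n3)nc2c1`, for which in this assay the entry reads "not determined" (no result reported). Compound 4 `Nc1nc(CSc2nc3ccccc3[nH]2)nc(Nc2ccc(Cl)cc2)n1` differs from compound 1 in one place: chloro in place of methoxy on an aromatic carbon. With no number for compound 1, the step to compound 4 cannot be measured; a change of this size is expected to shift the read-out by no more than the usual scatter, in either direction. Guided by compound 2 at 1500 ug/mL, compound 4 is estimated to give 1000 ug/mL in this assay, within a range from 300 ug/mL to 3000 ug/mL.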

Compound 4, half-maximal cytotoxic concentration: 1500 ug/mL
Estimate against measurement, compound 4: 1.5-fold (0.18 log units) below; measured number inside the range.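

Within the data shown here, compound 1 carries no number in this assay, so no step to compound 4 can be read. As far as these compounds go, whether chloro in place of methoxy shifts this read-out stays open, and no supporting evidence bears on the result of compound 4.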